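The compounds below may be only part of what the source reports. "The series", "measured", "known", "first", "only" and "open" are said of these compounds alone.

Measured in a functional assay on HEK293 cells for agonist activity at G-protein coupled receptor 39 (Homo sapiens), read by scintillation proximity assay and inositol phosphate accumulation, with a stated time of 75 min; on this read-out lower numbers stand for an effect already at smaller amounts and higher numbers for an effect only at larger amounts of compound:
compound 1 `Cc1nn(-c2ncnc3nc[nH]c23)c2c1C(OCc1ccccc1C#N)CC(=O)N2`: 127 nM
compound 2 `Cc1nn(-c2ncnc3nc[nH]c23)c2c1C(NC(=O)Cc1cccs1)CC(=O)N2`: 244 nM
compound 3 `Cc1nn(-c2ncnc3nc[nH]c23)c2c1C(C(=O)N(C)c1ccccc1)CC(=O)N2`: 5220 nM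

Compound 1 gives the lowest of the three numbers. The step to compound 2 is small (a 1.9-fold higher number from compound 1 to compound 2 (0.28 log units; within the scatter)), the step to compound 3 is large (a 41-fold higher number from compound 1 to compound 3 (1.61 log units; beyond the scatter)), and compound 2 to compound 3 is likewise large (a 21-fold higher number from compound 2 to compound 3 (1.33 log units; beyond the scatter)).

Compound 4 `COc1ccc(CCOC2CC(=O)Nc3c2c(C)nn3-c2ncnc3nc[nH]c23)cc1` differs from compound 1 by 4-methoxybenzyl in place of 2-cyanophenyl on a saturated chain carbon bound to an oxygen on a saturated carbon. The oxygen on the saturated ring carbon is kept; only the aryl part of the ether is exchanged. Both measured steps remove that oxygen entirely, so neither bears directly on this change, and they give no guide on the aryl part. A moderate step is expected, likely upward, a 2.4-fold higher number from compound 1 to compound 4 (0.37 log units; beyond the scatter); compound 4 is estimated at 300 nM (range 90 nM to 1000 nM).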

Compound 4, half-maximal effective concentration: 70 nM
Beside the measured number, compound 4's estimate is 4.3-fold (0.63 log units) above it, and the stated range ends above it.
By their numbers in this assay, from the lowest: compounds 4, 1 and 2 (each within the scatter of the next, the first and the last beyond it); then compound 3.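

Exchanging 2-cyanophenyl for 4-methoxybenzyl on a saturated chain carbon bound to an oxygen on a saturated carbon gives a 1.8-fold lower number from compound 1 to compound 4 (0.26 log units; within the scatter). In this assay, this arm therefore does not depend on the nitrile for a number of this order, and the longer 2-(4-methoxyphenyl)ethyl arm is accepted in place of 2-cyanobenzyl. No measurement at hand accounts for this result.

The compounds shown do not separate the contribution of the methoxy from that of the longer chain. A carboxylic acid or an amine on this aromatic ring remains an open case.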